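A few compounds are considered here, and "the series" means these few. Any claim that something is new, unique, unknown or untested is made for them only; others in the source may bear on it.

Compound 3 `CCOC(=O)c1cccc(-c2ccc(CN(C)C)cc2)c1` gives 67% in an assay on COS-7 cells for inhibition of patatin-like phospholipase domain-containing protein 2 (Mus musculus), tested at 200 uM (a lower number here means less inhibition, a higher number more inhibition at the concentration tested (going by the name of the read-out)), and stands lowest of the three numbers shown: compound 1 `CCOC(=O)c1cccc(-c2ccc(OCC)cc2)c1` gives 87% and compound 2 `CCOC(=O)c1cccc(-c2ccc(N(C)C)cc2)c1` gives 87%, and each of those lies beyond the scatter from compound 3. Compound 4 `CCOC(=O)c1cccc(-c2ccc(C(C)=O)cc2)c1` differs from compound 3 by a single change (acetyl in place of (dimethylamino)methyl on an aromatic carbon). For the measured compounds named here, two measured steps bear on this change. The step of a number 20 percentage points lower from compound 1 to compound 3 (beyond the scatter) and the step of a number 20 percentage points lower from compound 2 to compound 3 (beyond the scatter) both show the (dimethylamino)methyl group sitting below a group bound directly to the aromatic carbon, whether that group is ethoxy or dimethylamino, while the step of no change at the digits printed from compound 1 to compound 2 (within the scatter) shows those two directly bound groups giving alike numbers. The acetyl entering compound 4 is again bound directly to the ring, so a return toward the numbers of compound 1 and compound 2 is expected, with the caution that no acetyl has been measured in this series. Compound 4 is therefore expected to give 78% in this assay, within 60% to 92%, an estimated a number 11 percentage points higher from compound 3 to compound 4 (beyond the scatter).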

Compound 4, a percentage reported as inhibition, at one concentration (the size of the read-out at that concentration, not a potency): 36%
Estimate against measurement, compound 4: 42 percentage points above; the measured number lies below the stated range.
By their numbers in this assay, from the lowest: compound 4; then compound 3; then compounds 1 and 2 (each within the scatter of the next).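

In this assay, a group bound directly to the aromatic carbon does not by itself keep the number high at this position, para to a large group: acetyl gives a number 31 percentage points lower from compound 3 to compound 4 (beyond the scatter) and a number 51 percentage points lower from compound 2 to compound 4 (beyond the scatter) and a number 51 percentage points lower from compound 1 to compound 4 (beyond the scatter) and so stands lowest of the four compounds. For the compounds shown here, the swap from (dimethylamino)methyl to acetyl also leaves the count of hydrogen-bond acceptors unchanged and neither group carries a net charge, so those counts do not follow the drop, and this position proves able to move the number further than the earlier compounds showed. Nothing at hand accounts for the drop.

From the compounds shown here alone, it remains open whether the low number goes with the carbonyl or with acetyl as a whole. A carboxylic acid, a primary amide or a methyl ester at this place would bear on that question.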